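From 4-chlorophenyl to 3,5-dichlorophenyl on a sulfonamide nitrogen

The compounds below may be only part of what the source reports. "The series", "measured", "known", "first", "only" and "open" are said of these compounds alone.

Compound 1 `CCCN(CCC)c1c([N+](=O)[O-])cc(S(=O)(=O)Nc2ccc(Cl)cc2)cc1[N+](=O)[O-]` gives 16000 nM
Compound 2 `CCCN(CCC)c1c([N+](=O)[O-])cc(S(=O)(=O)Nc2cccc(OC)c2)cc1[N+](=O)[O-]` gives 36000 nM
Compound 3 `CCCN(CCC)c1c([N+](=O)[O-])cc(S(=O)(=O)Nc2cccc(C)c2)cc1[N+](=O)[O-]` gives 25000 nM

In a functional assay on PC-3 cells (Mus musculus) for cytotoxicity against PC-3 (Homo sapiens) (a lower number here means a stronger inhibitor, a higher number a weaker inhibitor), compound 1 holds no clear lead: the data show a 1.6-fold higher number from compound 1 to compound 3 (0.19 log units; within the scatter) and also a 2.3-fold higher number from compound 1 to compound 2 (0.35 log units; beyond the scatter) here. Compound 4 `CCCN(CCC)c1c([N+](=O)[O-])cc(S(=O)(=O)Nc2cc(Cl)cc(Cl)c2)cc1[N+](=O)[O-]` carries a new group on the same nitrogen: 3,5-dichlorophenyl in place of 4-chlorophenyl on a sulfonamide nitrogen in this change. Among the measured compounds shown here, no measured step makes this exact swap. The nearest evidence is the two steps above, plus a 1.4-fold lower number from compound 2 to compound 3 (0.16 log units; within the scatter) among the others, and none of these is large. The expected result is a 1.2-fold lower number from compound 1 to compound 4 (0.09 log units; within the scatter), so no shift beyond the scatter is anticipated. Compound 4 is estimated at 13000 nM, with an expected range of 6000 nM to 30000 nM overall.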

Compound 4, half-maximal inhibitory concentration: 11000 nM
Compound 4: the middle estimate sits 1.2-fold (0.07 log units) above what was measured; the range from low to high includes it.
By their numbers in this assay, from the lowest: compounds 4, 1, 3 and 2 (each within the scatter of the next, the first and the last beyond it).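

Replacing 4-chlorophenyl with 3,5-dichlorophenyl on the sulfonamide nitrogen gives no clear change in this assay, with a 1.5-fold lower number from compound 1 to compound 4 (0.16 log units; within the scatter), so the two chlorinated rings cannot be told apart. The new ring does separate from both other rings, with a 2.3-fold lower number from compound 3 to compound 4 (0.36 log units; beyond the scatter) and a 3.3-fold lower number from compound 2 to compound 4 (0.51 log units; beyond the scatter), whereas 3-methylphenyl stayed within the scatter of 4-chlorophenyl. No measurement shown accounts for these differences. The compounds shown leave open how a phenyl ring bearing an amine or a carboxylic acid, or a longer alkyl chain in place of the ring, would behave on this nitrogen.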